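The compounds below may be only part of what the source reports. "The series", "measured", "known", "first", "only" and "open" are said of these compounds alone.

Measured in a functional assay on BT-474 cells (Homo sapiens) for antiproliferative activity, read by sulforhodamine B assay, with a stated time of 4 days; on this read-out lower numbers stand for stronger inhibition of growth and higher numbers for weaker inhibition of growth:
- compound 1 `COc1cc(Cl)c(-c2nc(SCC(=O)NC(C)C)nc3[nH]cc(C#N)c23)cc1O`: 161 nM
- compound 2 `CCOc1cc(-c2nc(SCC(=O)NC(C)C)nc3[nH]cc(C#N)c23)c(Cl)cc1OC`: 84 nM
- compound 3 `COc1cc(Cl)c(-c2nc(SCC(=O)NC(C)C)nc3[nH]cc(C#N)c23)cc1OC`: 81 nM

Compound 3 stands level with the other two, as a 1.0-fold lower number from compound 2 to compound 3 (0.02 log units; within the scatter) and a 2.0-fold lower number from compound 1 to compound 3 (0.30 log units; within the scatter) show. Compound 4 `CNC(=O)CSc1nc(-c2cc(OC)c(OC)cc2Cl)c2c(C#N)c[nH]c2n1` has methyl in place of isopropyl on an amide-type nitrogen. Going by the values given here, no measured step touches that nitrogen, because all three measured compounds carry the isopropyl. The steps seen, such as a 1.9-fold lower number from compound 1 to compound 2 (0.28 log units; within the scatter), concern only groups on an oxygen on an aromatic ring, so they offer no direct guide. The data therefore give no firm reason to expect a clear change in this assay. The expected size is a 1.4-fold higher number from compound 3 to compound 4 (0.13 log units; within the scatter), which is a cautious guess. For compound 4 the estimate is 110 nM, with an expected range of 35 nM to 350 nM.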

Compound 4, concentration for 50% growth inhibition: 56 nM
Compound 4: the middle estimate sits 2.0-fold (0.29 log units) above what was measured, and the stated range covers the measured number.
By their numbers in this assay, from the lowest: compounds 4, 3, 2 and 1 (each within the scatter of the next, the first and the last beyond it).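

Going by these compounds alone, this is the first look at the amide-type nitrogen: methyl in place of isopropyl gives (a 1.4-fold lower number from compound 3 to compound 4 (0.16 log units; within the scatter)), so in compound 3 this nitrogen accepts the smaller group with no loss of growth inhibition beyond the scatter. Nothing measured here explains this result.

On these data alone, only isopropyl and methyl appear on this nitrogen, so it remains open how a longer chain, a cyclopropyl ring or a chain ending in an amine would behave. As far as these compounds go, whether the same swap holds alongside the ethoxy group of compound 2 also remains open.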